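This account rests on a few compounds, and the source may have more. Where it says the series, first, only, none or still open, it means among the compounds named here.

Measured in a functional assay on SK-BR-3 cells (Homo sapiens) for antiproliferative activity, read by MTT assay, with a stated time of 72 h; a higher number here means a weaker inhibitor, a lower number a stronger inhibitor:
- compound 1 `C=CC(=O)Nc1cc2c(Nc3ccc(OCc4cccc(F)c4)c(Cl)c3)ncnc2cc1OCc1cn(CCCC(=O)NO)nn1` gives 20200 nM
- compound 2 `C=CC(=O)Nc1cc2c(Nc3ccc(F)c(Cl)c3)ncnc2cc1OCc1cn(CCC(=O)NO)nn1` gives > 50000 nM

Compound 2 has no number, only the limit of the assay, > 50000 nM. Compound 3 `C=CC(=O)Nc1cc2c(Nc3ccc(F)c(Cl)c3)ncnc2cc1OCc1cn(CCCC(=O)NO)nn1` keeps everything in compound 2 except the chain, where 2-(hydroxycarbamoyl)ethyl becomes 3-(hydroxycarbamoyl)propyl: (hydroxycarbamoyl)methyl in place of hydroxycarbamoyl on a saturated chain carbon, two bonds along the chain from an aromatic nitrogen. The change is (hydroxycarbamoyl)methyl in place of hydroxycarbamoyl on a saturated chain carbon, two bonds along the chain from an aromatic nitrogen. Compound 1 carries the same 3-(hydroxycarbamoyl)propyl chain but differs elsewhere, so its 20200 nM is only a loose guide. In this assay, a small change toward stronger inhibition is expected, and another limit would be no surprise. The expected step is an at least 1.2-fold lower number from compound 2 to compound 3 (0.09 log units; that floor lies within the scatter). Compound 3 is estimated at 40000 nM, with an expected range of 18000 nM to 90000 nM.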

Compound 3, half-maximal inhibitory concentration: 30800 nM
Beside the measured number, compound 3's estimate is 1.3-fold (0.11 log units) above it; the measured number falls inside the stated range.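

In this assay, the 3-(hydroxycarbamoyl)propyl chain gives compound 3 a measured number where compound 2 has only a limit, and the change from 2-(hydroxycarbamoyl)ethyl gives an at least 1.6-fold lower number from compound 2 to compound 3 (0.21 log units; that floor lies within the scatter) on this chain. Compound 1 and compound 3 share that longer chain, and fluoro in place of (3-fluorobenzyl)oxy on an aromatic carbon gives a 1.5-fold higher number from compound 1 to compound 3 (0.18 log units; within the scatter) and so does not separate them. The step on the chain remains only a floor, because the value of compound 2 is a limit and not a number: the limit of > 50000 nM in this assay, at which 1 of the 3 values shown sits.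

Going by these compounds, how far the number would move with a still longer chain, such as 4-(hydroxycarbamoyl)butyl, stays open. So does what a carboxylic acid in place of hydroxycarbamoyl would give on the 3-(hydroxycarbamoyl)propyl position.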